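The source may report more compounds than this note shows. Statements on the series, on what has been measured and on what is new or still open speak of the compounds shown alone.

Of the compounds shown here, two of a shared core have been tested in an ADME assay on HepG2 2.2.15 cells (Homo sapiens) for cytotoxicity, read by MTT assay, with a stated time of 72 h; on this read-out lower numbers stand for higher toxicity in this test and higher numbers for lower toxicity in this test. Among the compounds with values here, compound 2 `N=C(N)c1cccc2c1CCOC2=O` gives 2050000 nM in this assay, and this is the only value reported as a number. Compound 1 `CCCCCCCC(=O)OCc1cccc2c1CCOC2=O` gives only a limit, > 3450000 nM, in this assay; the shape of the data is that (the limit of > 3450000 nM in this assay, at which 1 of the 2 values shown sits). Within the data shown here, because no two measured compounds differ in a single place, no step between them can be quoted, so compound 2 simply stands as the one defined point.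

Compound 3 `O=C1OCCc2c1cccc2C1OCCO1` is not yet measured. It differs from compound 2 in one place: a group of 5 heavy atoms (3 carbon, 2 oxygen; one five-membered non-aromatic ring with 2 hetero atoms) in place of a group of 3 heavy atoms (1 carbon, 2 nitrogen; no ring), on an aromatic carbon. With nothing to set the size of such a change, the expected step in this assay from compound 2 to compound 3 is a 1.2-fold higher number from compound 2 to compound 3 (0.09 log units; within the scatter), which is not expected to reach beyond the scatter. Compound 3 is therefore estimated at 2500000 nM, with a range from 800000 nM to 8000000 nM, and there is a fair chance that only a limit is reported.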

Compound 3, half-maximal cytotoxic concentration: > 2580000 nM
Compound 3: no number, only a limit (the forecaster's own chance of this, stated with the estimate: 40%); middle value at least 1.0-fold (0.01 log units) from the limit.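

In this assay putting 1,3-dioxolan-2-yl on this aromatic carbon, in place of the open group with two nitrogens, gives an at least 1.2-fold higher number from compound 2 to compound 3 (0.09 log units; that floor lies within the scatter). Compound 3 gives only a limit, not a number: the limit of > 2580000 nM in this assay, at which 1 of the 3 values shown sits. Nothing here shows the ring making the compound more toxic in this test than the group it replaces, and this position accepts both groups without a clear separation between them, since the floor of the step does not set the two compounds apart.

On these data alone, how far the true value of compound 3 lies from that of compound 2 remains open. Also open, as far as these compounds go, is whether an amine, a carboxylic acid or a longer chain on this aromatic carbon would give a clearly lower number in this test.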